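Methylsulfonyl in Place of Methyl: What the Limits Allow

A few compounds are considered here, and "the series" means these few. Any claim that something is new, unique, unknown or untested is made for them only; others in the source may bear on it.

Compound 1 `Cc1ccc(-c2csc(N3N=C(c4ccc(C)s4)CC3c3ccc(F)cc3)n2)cc1` gives > 500 ug/mL in an ADME assay on NIH3T3 cells (Mus musculus) for cytotoxicity, read by XTT assay, with a stated time of 24 h (a higher number here means a weaker inhibitor, a lower number a stronger inhibitor), a limit of the assay rather than a number.
Compound 2 `Fc1ccc(C2CC(c3ccc(Cl)s3)=NN2c2nc(-c3ccc(C(F)(F)F)cc3)cs2)cc1` gives > 500 ug/mL in this assay, also a limit.
Compound 3 `N#Cc1ccc(-c2csc(N3N=C(c4ccc(Cl)s4)CC3c3ccc(F)cc3)n2)cc1` gives > 500 ug/mL in this assay, again a limit.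

Among the measured compounds shown here, compound 1 stands only at a limit, and the two other values shown are limits as well, so no compound can be placed above or below another. For the measured compounds named here, the one step between measured compounds that differ in a single place, a step that the two limits leave unreadable from compound 2 to compound 3, is unreadable because the limit of > 500 ug/mL in this assay, at which 3 of the 3 values shown sit, holds both of its ends.

Compound 4 `Cc1ccc(C2=NN(c3nc(-c4ccc(S(C)(=O)=O)cc4)cs3)C(c3ccc(F)cc3)C2)s1` differs from compound 1 by methylsulfonyl in place of methyl on an aromatic carbon. Going by the values given here, no measured step bears directly on this change, and the only measured step is itself unreadable; what the data show is that every value so far sits at the same limit because the limit of > 500 ug/mL in this assay, at which 3 of the 3 values shown sit, covers all three. The step expected is therefore a number no higher from compound 1 to compound 4 (the limit leaves the size open), none beyond the scatter, with the assay most likely reporting a limit again. Compound 4 is expected to give 500 ug/mL, within 200 ug/mL to 1000 ug/mL.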

Compound 4, half-maximal inhibitory concentration: 374 ug/mL
For compound 4 the middle estimate is 1.3-fold (0.13 log units) above the measured one; measured number inside the range.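

Of the compounds shown, only compound 4 gives a number rather than a limit in this assay, and it does so with methylsulfonyl on an aromatic carbon of the six-membered aromatic ring, para to a large group. This change reads as an at least 1.3-fold lower number from compound 1 to compound 4 (0.12 log units; that floor lies within the scatter), which gives the position its first step with a direction, though only its floor is known. The true size of the step stays open because compound 1 stands at a limit: the limit of > 500 ug/mL in this assay, at which 3 of the 4 values shown sit.

The compounds shown leave open whether methylsulfonyl would give a number alongside the chlorine that compound 2 and compound 3 carry. They also leave open what an amine or a carboxylic acid at this position would give in this assay.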